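Swapping the aryl group on the pyridazinone nitrogen

The compounds below may be only part of what the source reports. "The series", "measured", "known", "first", "only" and "open" are said of these compounds alone.

Measured so far:
compound 1, `COc1cc2c(Oc3ccc(NC(=O)c4nn(-c5ccccc5)c(=O)cc4C)cc3F)ccnc2cc1OCCCN1CCCC1`: 1100 nM
compound 2, `COc1ccc(-n2nc(C(=O)Nc3ccc(Oc4ccnc5cc(OCCCN6CCCC6)c(OC)cc45)c(F)c3)c(C)cc2=O)cc1`: 2960 nM

Both compounds were tested in a functional assay on U-87MG ATCC cells (Homo sapiens) for inhibition, read by MTT assay, with a stated time of 72 h; a lower number here means a stronger inhibitor, a higher number a weaker inhibitor. Compound 2, `COc1ccc(-n2nc(C(=O)Nc3ccc(Oc4ccnc5cc(OCCCN6CCCC6)c(OC)cc45)c(F)c3)c(C)cc2=O)cc1`, gives the highest of the two numbers: in this assay compound 2 gives 2960 nM, whereas compound 1 gives 1100 nM. Among the compounds with values here, the single step between them, methoxy in place of hydrogen on an aromatic carbon, was a 2.7-fold higher number from compound 1 to compound 2 (0.43 log units; beyond the scatter).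

Compound 3, `COc1cc2c(Oc3ccc(NC(=O)c4nn(-c5ccc(F)c(F)c5)c(=O)cc4C)cc3F)ccnc2cc1OCCCN1CCCC1`, has not yet been measured. It differs from compound 2 in one place: 3,4-difluorophenyl in place of 4-methoxyphenyl on an aromatic nitrogen. Within the data shown here, no measured step involves fluorine on this ring, so the only guide is the step from compound 1 to compound 2, which showed that adding a methoxy group at this position raised the number. Removing that methoxy and putting two fluorines on the ring is a different change, so the direction is uncertain. The estimate for compound 3 is 1500 nM, with a range of 500 nM to 5000 nM. This expected step, a 2.0-fold lower number from compound 2 to compound 3 (0.30 log units; within the scatter), would leave compound 3 somewhat closer to compound 1 than to compound 2.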

Compound 3, half-maximal inhibitory concentration: 1400 nM
For compound 3 the middle estimate is 1.1-fold (0.03 log units) above the measured one, within the range that was stated.
By their numbers in this assay, from the lowest: compounds 1 and 3 (each within the scatter of the next); then compound 2.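

Placing 3,4-difluorophenyl on the aromatic nitrogen in place of phenyl gave a 1.3-fold higher number from compound 1 to compound 3 (0.10 log units; within the scatter) in this assay, so the two compounds cannot be told apart, and a substituted ring at this position does not have to raise the number. Putting the same group in place of 4-methoxyphenyl gave a 2.1-fold lower number from compound 2 to compound 3 (0.33 log units; beyond the scatter), a modest step that recovers the rise seen with the methoxy group. Among these three compounds, then, only the 4-methoxyphenyl of compound 2 stands apart, while compound 3 shows that the rise does not come with every added ring substituent, and nothing measured here explains the difference between these groups.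

Going by these compounds, only hydrogen, methoxy and fluorine appear on this ring, so it remains open how the number would respond to an amine, a carboxylic acid or a longer chain such as butoxy. On these data alone, it is also open whether a single fluorine would read like the pair in 3,4-difluorophenyl, and whether methoxy would raise the number when placed elsewhere on the ring.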